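This account rests on a few compounds, and the source may have more. Where it says the series, first, only, none or still open, it means among the compounds named here.

Working notes on the series. Going by the values given here, compound 1 `COc1ccc(Sc2ccc(Sc3nncn3C)nc2C(=O)Nc2ncc(SCC(=O)O)s2)cc1` was measured in a physicochemical assay for permeability (a higher number here means that the compound crosses the layer faster, a lower number that the compound crosses the layer more slowly), and gives 2 10^-6 cm/s, the only number in hand for this group. Compound 2 `COc1ccc(Sc2ccc(Sc3ccccn3)nc2C(=O)Nc2ncc(CCC(=O)O)s2)cc1` gives "not determined" (no result reported) in this assay; no result was reported for it, so compound 2 stands on no number of its own, and nothing can be said of its position relative to compound 1.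

Compound 3 `COc1ccc(Sc2ccc(Sc3ccccn3)nc2C(=O)Nc2nc(CC(=O)O)c(Cl)s2)cc1` has not yet been measured. It differs from compound 2 in one place: 4-(carboxymethyl)-5-chloro-1,3-thiazol-2-yl in place of 5-(2-carboxyethyl)-1,3-thiazol-2-yl on an amide-type nitrogen. The carboxylic acid remains in both, carried on a chain of different length, and a chlorine is added on the thiazolyl ring.

Among the compounds with values here, with no measured step in this assay between compounds that differ in one place, the size and direction of the step from compound 2 to compound 3 cannot be read from the data; a step of no more than the usual scatter is expected, in either direction. The expectation for compound 3 rests on compound 1, because compound 1 gives 2 10^-6 cm/s and also carries a carboxylic acid. Compound 3 is estimated at 2 10^-6 cm/s in this assay, with a range from 0.5 10^-6 cm/s to 8 10^-6 cm/s.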

Compound 3, apparent permeability: 22 10^-6 cm/s
Compound 3: the middle estimate sits 11-fold (1.04 log units) below what was measured; measured number outside the range, above it.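

Going by these compounds alone, compound 2 has no number in this assay, so no step from compound 2 to compound 3 can be read. The compounds shown leave open what replacing 5-(2-carboxyethyl)-1,3-thiazol-2-yl with 4-(carboxymethyl)-5-chloro-1,3-thiazol-2-yl does in this assay. No supporting data bear on the result for compound 3.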